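This account rests on a few compounds, and the source may have more. Where it says the series, first, only, none or still open, it means among the compounds named here.

Measured so far in a functional assay on Calu-1 cells (Homo sapiens) for cytotoxicity, read by resazurin assay, with a stated time of 72 h; on this read-out lower numbers stand for stronger inhibition and higher numbers for weaker inhibition:
compound 1 `O=C(/C=C/c1ccc(OCCCCCO[N+](=O)[O-])c(O)c1)OCCCCCO[N+](=O)[O-]`: compound 1 gives > 50000 nM, a limit of the assay and not a number.
compound 2 `COc1cc(/C=C/C(=O)OCCCO[N+](=O)[O-])ccc1OCCCO[N+](=O)[O-]`: compound 2 gives 1420 nM.
compound 3 `COc1cc(/C=C/C(=O)OCCCCCO[N+](=O)[O-])ccc1OCCCCCO[N+](=O)[O-]`: compound 3 gives > 50000 nM, again a limit of the assay.

Going by the values given here, compound 2 thus holds the only number in this assay; the other two values are limits. Compound 3 and compound 1 differ by hydrogen in place of methyl on an oxygen on an aromatic ring. The step that the two limits leave unreadable from compound 3 to compound 1 stays unreadable because the limit of > 50000 nM in this assay, at which 2 of the 3 values shown sit, holds both ends of it, so the size of this change has not been seen yet.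

Compound 4 `O=C(/C=C/c1ccc(OCCCO[N+](=O)[O-])c(O)c1)OCCCO[N+](=O)[O-]` is not yet measured. Among the compounds with values here, it differs from compound 2 by hydrogen in place of methyl on an oxygen on an aromatic ring, the same change as the one from compound 3 to compound 1. How the core of compound 2 differs from that of compound 3 is not broken down here.

With no readable precedent, the expectation rests on compound 2 alone at 1420 nM, and compound 4 is expected to sit within the same general region. Compound 4 is estimated at 3000 nM, likely between 700 nM and 30000 nM. This estimate means an expected step of a 2.1-fold higher number from compound 2 to compound 4 (0.32 log units; beyond the scatter), held loose on purpose, since the unread size of a step that the two limits leave unreadable from compound 3 to compound 1 leaves room for a limit rather than a number.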

Compound 4, half-maximal inhibitory concentration: 12500 nM
Estimate against measurement, compound 4: 4.2-fold (0.62 log units) below; the measured number falls inside the stated range.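

In this assay, the change from methoxy to hydroxy on the core of compound 2 gives an 8.8-fold higher number from compound 2 to compound 4 (0.94 log units; beyond the scatter), so on this core the change has a readable size and raises the number. The same change from compound 3 to compound 1 cannot be read, because compound 3 and compound 1 both stand at one limit of the assay and not at numbers: the limit of > 50000 nM in this assay, at which 2 of the 4 values shown sit.
The series therefore offers one readable instance on one core, which shows nothing about whether the change keeps its size or direction on the core of compound 3, and no transfer between the two cores can be claimed.

Left open is how this assay would read for the core of compound 4 with an amine or a carboxylic acid in place of the hydroxy. Also open, from the compounds shown here alone, is whether a further core with a readable number would show the methoxy to hydroxy change at a similar size to the one seen here.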